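A few compounds are considered here, and "the series" means these few. Any claim that something is new, unique, unknown or untested is made for them only; others in the source may bear on it.

Measured compounds:

compound 1, `COc1ncc(-c2ccc3ncnc(N[C@H]4CCCN(C(=O)C5CCNCC5)C4)c3c2)cc1C#N`, 2440 nM
compound 2, `COc1ncc(-c2ccc3ncnc(N[C@H]4CCCN(C(=O)CCl)C4)c3c2)cc1C#N`, 380 nM
compound 3, `COc1ncc(-c2ccc3ncnc(N[C@H]4CCCN(C(=O)C(C)N)C4)c3c2)cc1C#N`, 440 nM

In a functional assay on SU-DHL-6 cells (Homo sapiens) for antiproliferative activity, read by MTT assay (on this read-out lower numbers stand for stronger inhibition and higher numbers for weaker inhibition), compound 3 stands second of the three numbers, with compound 2 within the scatter of it and compound 1 clearly weaker, as the step of a 5.5-fold lower number from compound 1 to compound 3 (0.74 log units; beyond the scatter) shows. Compound 4 is `COc1ncc(-c2ccc3ncnc(N[C@H]4CCCN(C(=O)c5coc([N+](=O)[O-])c5)C4)c3c2)cc1C#N`; the change is 5-nitrofuran-3-yl in place of 1-aminoethyl on a carbonyl carbon. The measured steps that bear on this are all swaps on the same carbonyl carbon: a 6.4-fold lower number from compound 1 to compound 2 (0.81 log units; beyond the scatter), a 5.5-fold lower number from compound 1 to compound 3 (0.74 log units; beyond the scatter) and a 1.2-fold higher number from compound 2 to compound 3 (0.06 log units; within the scatter). Two small groups gave near-identical numbers, while the larger ring of compound 1 gave a weaker result. A 5-nitrofuran-3-yl group is aromatic and resembles none of those, so a modest weakening is expected, a 2.0-fold higher number from compound 3 to compound 4 (0.31 log units; beyond the scatter), and compound 4 is expected near 900 nM, within 300 nM to 3000 nM.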

Compound 4, half-maximal inhibitory concentration: 140 nM
Compound 4: middle estimate off by 6.4-fold (0.81 log units), on the high side, outside the stated range (below it).
By their numbers in this assay, from the lowest: compound 4; then compounds 2 and 3 (each within the scatter of the next); then compound 1.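

In this assay this carbonyl carbon takes an aromatic ring and the number falls, with a 3.1-fold lower number from compound 3 to compound 4 (0.50 log units; beyond the scatter) and a 2.7-fold lower number from compound 2 to compound 4 (0.43 log units; beyond the scatter) showing that the small groups do not set the limit here. A ring alone does not decide the outcome, since the two ring-bearing groups differ by a 17-fold lower number from compound 1 to compound 4 (1.24 log units; beyond the scatter) even though both are larger than the small groups. Nothing measured here explains these differences. Still open, as far as these compounds go, is whether the nitro group or the furan ring drives the drop, and how a plain phenyl ring or a furan carrying an amine would read.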